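The source may hold more compounds than are shown below. What is called first, only, known or untested is meant among the compounds shown, and "the series" means these compounds.

Compound 1 `N[C@@H](COP(=O)(O)OCCCOC(=O)CCc1ccccc1OCc1cccc(Oc2ccc(Cl)cc2)c1)C(=O)O` gives 0.76 in an assay on cells for activation of probable G-protein coupled receptor 34 (Mus musculus), with a stated time of 1 h; on this read-out lower numbers stand for smaller maximal responses and higher numbers for larger maximal responses.
Compound 2 `N[C@@H](COP(=O)(O)OCCCOC(=O)CCc1ccccc1OCc1cccc(Oc2ccc(Br)cc2)c1)C(=O)O` gives 0.97 in this assay.

Of the two compounds measured in this assay, compound 2 stands highest, with compound 1 nearest at a step of a number 0.21 higher from compound 1 to compound 2 (beyond the scatter). Compound 3 `N#Cc1ccc(Oc2cccc(COc3ccccc3CCC(=O)OCCCOP(=O)(O)OC[C@H](N)C(=O)O)c2)cc1` is not yet measured and differs from compound 2 by cyano in place of bromo on an aromatic carbon. Going by the values given here, the only measured step, a number 0.21 higher from compound 1 to compound 2 (beyond the scatter), concerns the exchange of one halogen for another at this same aromatic carbon, so it bears on the new step only loosely: it shows that this position can shift the maximal response beyond the scatter, but gives no direction for a cyano group. The step from compound 2 to compound 3 is therefore expected to be a number 0.15 lower from compound 2 to compound 3 (beyond the scatter), a modest drop that may well fall within the scatter. Compound 3 is estimated to reach 0.82, within a range from 0.58 to 1.04.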

Compound 3, intrinsic activity: the largest response reached, as a fraction of the reference agonist's: 0.041
Compound 3: middle estimate off by 0.78, on the high side; measured number outside the range, below it.
By their numbers in this assay, from the lowest: compound 3; then compound 1; then compound 2.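

Cyano in place of bromo on this aromatic carbon brings a number 0.93 lower from compound 2 to compound 3 (beyond the scatter) in this assay, and cyano in place of chloro brings a number 0.72 lower from compound 1 to compound 3 (beyond the scatter). Both steps are much larger than the one between the two halogens, a number 0.21 higher from compound 1 to compound 2 (beyond the scatter), so the group at this carbon, para to a large group, can do more than adjust a high maximal response: with cyano, compound 3 gives only 0.041 on an otherwise unchanged structure. The data given offer no explanation for the sharp difference between cyano and the two halogens.

The compounds shown leave open how a hydrogen, a methyl group or a methoxy group at this carbon would behave. They therefore cannot say whether the high responses belong to the halogens or the low one to cyano alone.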